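Methylsulfanyl to Benzylselanyl on a Shared Quinoline Amide Core

The source may report more compounds than this note shows. Statements on the series, on what has been measured and on what is new or still open speak of the compounds shown alone.

Measured compounds:
Compound 1 `C[Se]/C(=N\C(=O)c1cnc2ccccc2c1)NC(=O)c1cnc2ccccc2c1` gives 4160 nM.
Compound 2 `CS/C(=N\C(=O)c1cnc2ccccc2c1)NC(=O)c1cnc2ccccc2c1` gives 57600 nM.

Both were tested in a functional assay on HepG2 cells (Homo sapiens) for cytotoxicity, read by MTT assay, with a stated time of 72 h; on this read-out lower numbers stand for stronger inhibition of growth and higher numbers for weaker inhibition of growth. Compound 2 stands highest of the two numbers, and its nearest neighbour is compound 1, which differs only at the carbon with a double bond to nitrogen. That single step, a 14-fold higher number from compound 1 to compound 2 (1.14 log units; beyond the scatter), shows that replacing the selenium-bearing group with its sulfur counterpart weakened growth inhibition markedly.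

Compound 3 `O=C(/N=C(/NC(=O)c1cnc2ccccc2c1)[Se]Cc1ccccc1)c1cnc2ccccc2c1` carries, in place of the methylsulfanyl of compound 2, (a group of 8 heavy atoms (7 carbon, 1 selenium; one six-membered aromatic ring of carbon only) in place of a group of 2 heavy atoms (1 carbon, 1 sulfur; no ring), on a carbon with a double bond to nitrogen). Going by the values given here, this change returns selenium to the same position, which bears directly on the measured step, while also adding the six-membered aromatic ring; no measured pair speaks to that addition.

Compound 3 is therefore expected to show a step of about a 12-fold lower number from compound 2 to compound 3 (1.06 log units; beyond the scatter), a return towards stronger growth inhibition. Compound 3 is estimated at 5000 nM, within 1500 nM to 20000 nM.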

Compound 3, concentration for 50% growth inhibition: 8540 nM
Beside the measured number, compound 3's estimate is 1.7-fold (0.23 log units) below it; measured number inside the range.
By their numbers in this assay, from the lowest: compound 1; then compound 3; then compound 2.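

In this assay, replacing methylsulfanyl with the selenium group that carries a six-membered aromatic ring gives a 6.7-fold lower number from compound 2 to compound 3 (0.83 log units; beyond the scatter), so this carbon with a double bond to nitrogen accepts a much bigger group without losing growth inhibition. Phenyl in place of hydrogen on the saturated chain carbon bound to selenium gives a 2.1-fold higher number from compound 1 to compound 3 (0.31 log units; beyond the scatter), a modest weakening that is just beyond the scatter, so most of the advantage seen with selenium survives the added ring. No measurement at hand explains either step.

Going by these compounds, it remains open how a sulfur atom carrying the same phenyl-bearing chain would compare, which would test the ring on the sulfur series as well. A longer chain on selenium, such as propyl, or an amine on the added ring, could also show how much change this position tolerates.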